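Unmasking the phenol: from compound 3 to compound 4

A few compounds are considered here, and "the series" means these few. Any claim that something is new, unique, unknown or untested is made for them only; others in the source may bear on it.

Compound 1 `O=C1Nc2ccc(C(=O)c3ccco3)cc2/C1=C/c1cc(Br)c(O)c(Br)c1`: 65%
Compound 2 `O=C1Nc2ccc(C(=O)c3ccco3)cc2/C1=C/c1cc(Br)cc(Br)c1`: 16%
Compound 3 `COc1ccc(/C=C2\C(=O)Nc3ccc(C(=O)c4ccco4)cc32)cc1Br`: 2.3%

All three share one core and differ only in the ring that hangs from the double bond. In an assay on HeLa cells for inhibition of Kinesin-like protein KIF15 (Homo sapiens), read by microscopy, with stated times of 2 s and 20 s, tested at 750 nM (on this read-out lower numbers stand for less inhibition and higher numbers for more inhibition at the one concentration tested (going by the name of the read-out)), compound 1 gives 65%, the highest of the three numbers. Compound 3 stands lowest: its nearest neighbour is compound 2, whose number is higher beyond the scatter, and compound 1 lies furthest above it.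

Compound 4 `O=C1Nc2ccc(C(=O)c3ccco3)cc2/C1=C/c1ccc(O)c(Br)c1` is not yet measured. It differs from compound 3 by hydrogen in place of methyl on an oxygen on an aromatic ring.

Two measured steps speak to this. Removing the hydroxy gave a number 49 percentage points lower from compound 1 to compound 2 (beyond the scatter), a large loss, so a free hydroxy on that ring counts. Exchanging the hydroxy-bearing ring for the methoxy-bearing ring gave a number 62.7 percentage points lower from compound 1 to compound 3 (beyond the scatter), though a bromine also left there. Returning the hydroxy in compound 4 is therefore expected to raise the number, by roughly a number 32.7 percentage points higher from compound 3 to compound 4 (beyond the scatter), short of compound 1 since one bromine is still missing. Compound 4 is estimated at 35%, within 10% to 60%.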

Compound 4, a percentage reported as inhibition, at one concentration (the size of the read-out at that concentration, not a potency): 23%
Compound 4: middle estimate off by 12 percentage points, on the high side; low and high end bracket the measured number.
By their numbers in this assay, from the lowest: compound 3; then compounds 2 and 4 (each within the scatter of the next); then compound 1.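

In this assay, removing the methyl from the oxygen gives a number 20.7 percentage points higher from compound 3 to compound 4 (beyond the scatter), which isolates the cost of that methyl, whereas the earlier step from compound 1 to compound 3 also removed a bromo. The free hydroxy is not enough on its own: hydrogen in place of bromo gives a number 42 percentage points lower from compound 1 to compound 4 (beyond the scatter), so the high number needs both groups, while a number 7 percentage points higher from compound 2 to compound 4 (within the scatter) leaves the 3-bromo-4-hydroxyphenyl and 3,5-dibromophenyl rings indistinguishable here. No supporting information explains these shifts.

The compounds shown leave open whether an amine or a carboxylic acid could take the place of the hydroxy, and whether an ethoxy would behave like the methoxy. They also leave open whether a chloro could stand in for the missing bromo.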